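Swapping hydroxyl positions on a pyridine-free core, one step more

This account rests on a few compounds, and the source may have more. Where it says the series, first, only, none or still open, it means among the compounds named here.

All values below come from a functional assay on T47D cells (Homo sapiens) for inhibition; a higher number here means a weaker inhibitor, a lower number a stronger inhibitor.

Compound 1, `Oc1cccc(-c2cc(-c3ccc(OC(F)(F)F)cc3)cc(-c3ccccc3O)n2)c1`: 7710 nM
Compound 2, `Oc1ccc(-c2cc(-c3ccc(OC(F)(F)F)cc3)cc(-c3ccccc3O)n2)cc1`: > 50000 nM, which is a limit of the assay rather than a number
Compound 3, `Oc1cccc(-c2cc(-c3ccc(OC(F)(F)F)cc3)cc(-c3cccc(O)c3)n2)c1`: 9820 nM

Compound 3 and compound 1 lie within the scatter of each other, the step between them being a 1.3-fold higher number from compound 1 to compound 3 (0.11 log units; within the scatter). Compound 2 sits at the limit of > 50000 nM in this assay, at which 1 of the 3 values shown sits.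

Compound 4, `Oc1ccc(-c2cc(-c3ccc(OC(F)(F)F)cc3)cc(-c3cccc(O)c3)n2)cc1`, is built from compound 3 by 4-hydroxyphenyl in place of 3-hydroxyphenyl on an aromatic carbon. The same exchange of a 3-hydroxyphenyl for a 4-hydroxyphenyl has been made once before, on the other hydroxyphenyl group of the shared core, and gave an at least 6.4-fold higher number from compound 1 to compound 2 (0.81 log units; beyond the scatter). Within the data shown here, that is the only step that bears on the new one, and it points to weaker inhibition. A step of similar size is therefore expected from compound 3 to compound 4, a 6.1-fold higher number from compound 3 to compound 4 (0.79 log units; beyond the scatter), quite possibly reaching the limit of the assay again. Compound 4 is expected to give about 60000 nM, with a likely range from 20000 nM to 200000 nM.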

Compound 4, half-maximal inhibitory concentration: 18900 nM
The estimate for compound 4 lay 3.2-fold (0.50 log units) above the measured number; the whole stated range lies above it.
By their numbers in this assay, from the lowest: compounds 1, 3 and 4 (each within the scatter of the next, the first and the last beyond it). At a limit, above all of these: compound 2.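

In this assay, the exchange of 3-hydroxyphenyl for 4-hydroxyphenyl at this position gives only a 1.9-fold higher number from compound 3 to compound 4 (0.28 log units; within the scatter), so the change carries no fixed penalty and its effect depends on the hydroxyphenyl group elsewhere on the core: the same change on two cores in this assay, an at least 6.4-fold higher number (0.81 log units; beyond the scatter) from compound 1 to compound 2 and a 1.9-fold higher number (0.28 log units; within the scatter) from compound 3 to compound 4, at least 3.3-fold (0.52 log units) apart, beyond the scatter of two such steps

Read against the limit of compound 2, the change to a 3-hydroxyphenyl group gives an at least 2.6-fold lower number from compound 2 to compound 4 (0.42 log units; beyond the scatter), whereas the same change showed no clear effect when made from compound 1 to compound 3: the same change on two cores in this assay, a 1.3-fold higher number (0.11 log units; within the scatter) from compound 1 to compound 3 and an at least 2.6-fold lower number (0.42 log units; beyond the scatter) from compound 2 to compound 4, at least 3.3-fold (0.52 log units) apart, beyond the scatter of two such steps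

A 4-hydroxyphenyl group can thus coexist with measurable inhibition, although a 2.5-fold higher number from compound 1 to compound 4 (0.39 log units; beyond the scatter).

The compounds shown leave open whether the hydroxyl itself is needed at this position, as a methoxy group or an amine in its place would show. They also leave open whether the dependence between the two groups persists when the trifluoromethoxy group is replaced.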